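Swapping Chloro for Methoxy on a Shared Core

The source may hold more compounds than are shown below. What is called first, only, known or untested is meant among the compounds shown, and "the series" means these compounds.

Of the compounds shown here, three on one shared core have been measured in a functional assay on MCF7 cells (Homo sapiens) for cytotoxicity, read by sulforhodamine B assay, with a stated time of 48 h, in the presence of a further agent that is not named here; on this read-out higher numbers stand for weaker inhibition of growth and lower numbers for stronger inhibition of growth. Compound 1 `CCCCNc1ccnc2cc(Cl)ccc12` gives 10200 nM. Compound 2 `CN(C)CCNc1ccnc2cc(Cl)ccc12` gives 4960 nM, and compound 3 `CN(C)CCNc1ccnc2cc(F)ccc12` gives 2560 nM. Among these three numbers compound 2 stands second highest: compound 3 lies a 1.9-fold lower number from compound 2 to compound 3 (0.29 log units; within the scatter) away, while compound 1 sits at a 2.1-fold lower number from compound 1 to compound 2 (0.31 log units; beyond the scatter) on the other side.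

Compound 4 `COc1ccc2c(NCCN(C)C)ccnc2c1` has not yet been measured. It differs from compound 2 in a single place: methoxy in place of chloro on an aromatic carbon. The step that bears most directly on this change is the one already seen at the same aromatic carbon, where fluoro replaced chloro, a 1.9-fold lower number from compound 2 to compound 3 (0.29 log units; within the scatter). That halogen swap stayed within the scatter. The other known step, from compound 1 to compound 2, concerns the saturated chain and says nothing about the aromatic ring. On this thin evidence, a small downward move or none at all is expected in this assay , not a large one in either direction, since a group change at this carbon has so far left the number roughly where it was.

Compound 4 is therefore expected to give about 4000 nM, within a range of 1500 nM to 11000 nM, which means an expected step of a 1.2-fold lower number from compound 2 to compound 4 (0.09 log units; within the scatter).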

Compound 4, concentration for 50% growth inhibition: 3540 nM
For compound 4 the middle estimate is 1.1-fold (0.05 log units) above the measured one, and the stated range covers the measured number.
By their numbers in this assay, from the lowest: compounds 3, 4 and 2 (each within the scatter of the next); then compound 1.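

Until now, this aromatic carbon had only carried two halogens, chloro and fluoro, so it was unclear whether a group of another kind would leave the number in place. Methoxy is such a group, with two heavy atoms instead of one and a hydrogen-bond acceptor that chloro lacks, yet in this assay the result is a 1.4-fold lower number from compound 2 to compound 4 (0.15 log units; within the scatter) and, against the fluoro compound, a 1.4-fold higher number from compound 3 to compound 4 (0.14 log units; within the scatter). Both steps stay within the scatter, so compounds 2, 3 and 4 cannot be told apart in this assay, and across these three groups the change at this carbon has no readable effect on the number, while nothing shown gives a measured reason for this sameness.

On these data alone, three groups at one carbon are a narrow sample, and it remains open whether an amine, a carboxylic acid or a much larger group such as phenyl would also leave the number in place. As far as these compounds go, it is also open whether methoxy would behave the same way on the core of compound 1, which carries the butyl chain instead of the dimethylamino chain.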